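The source may report more compounds than this note shows. Statements on the series, on what has been measured and on what is new or still open speak of the compounds shown alone.

Series in a functional assay on HepG2 cells (Homo sapiens) for inhibition, read by MTT assay, with a stated time of 24 h; on this read-out lower numbers stand for stronger inhibition of growth and higher numbers for weaker inhibition of growth:
- compound 1 `Cn1cc(-c2nc3ccccc3n2C(=O)c2ccccc2)c2ccccc21`: 42300 nM
- compound 2 `COc1ccc(C(=O)n2c(-c3cn(C)c4ccccc34)nc3ccccc32)cc1`: 15200 nM
- compound 3 `COc1cc(C(=O)n2c(-c3cn(C)c4ccccc34)nc3ccccc32)cc(OC)c1OC`: 4300 nM

Of these three numbers, compound 2 has the second highest. Its value of 15200 nM lies between those of compound 1 at 42300 nM and compound 3 at 4300 nM.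

The next structure is compound 4 `Cn1cc(-c2nc3ccccc3n2C(=O)c2cccc(Br)c2)c2ccccc21`, and the change from compound 2 is 3-bromophenyl in place of 4-methoxyphenyl on a carbonyl carbon. In words, this is 3-bromophenyl in place of 4-methoxyphenyl on a carbonyl carbon.

Among the measured compounds shown here, only one measured step bears on this change: a 2.8-fold lower number from compound 1 to compound 2 (0.44 log units; beyond the scatter), a modest step with methoxy in place of hydrogen on an aromatic carbon. For the measured compounds named here, compound 4 has no methoxy, but no measured compound carries bromine, so that step gives only a rough guide. A slightly higher number is expected in this assay, with no step beyond the scatter. The estimated step is a 1.3-fold higher number from compound 2 to compound 4 (0.12 log units; within the scatter).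

For compound 4 the expected value is 20000 nM, with an estimated range of 7000 nM to 50000 nM.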

Compound 4, concentration for 50% growth inhibition: 61400 nM
For compound 4 the middle estimate is 3.1-fold (0.49 log units) below the measured one; the whole stated range lies below it.
By their numbers in this assay, from the lowest: compound 3; then compound 2; then compounds 1 and 4 (each within the scatter of the next).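

In this assay the group on the carbonyl carbon turns out to matter in both directions, not only in the one methoxy showed: 3-bromophenyl in place of 4-methoxyphenyl gives a step beyond the scatter (a 4.0-fold higher number from compound 2 to compound 4 (0.61 log units; beyond the scatter)). Bromo in place of hydrogen on an aromatic carbon stays within the scatter (a 1.5-fold higher number from compound 1 to compound 4 (0.16 log units; within the scatter)), so bromo at this place shows no measurable shift from the plain phenyl of compound 1. Read beside the methoxy step (a 2.8-fold lower number from compound 1 to compound 2 (0.44 log units; beyond the scatter)), the step to compound 4 amounts to losing what methoxy gave, not to a separate step from bromo beyond the scatter.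

Open, going by these compounds, is whether the outcome for compound 4 belongs to bromine itself or to where it sits, since 4-methoxyphenyl and 3-bromophenyl differ in both, and how an amine or a carboxylic acid on this ring would read. Nothing at hand explains these steps.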